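The source may hold more compounds than are shown below. What is called first, only, known or untested is meant among the compounds shown, and "the series" means these compounds.

Measured in an assay on VSM-A10 cells for antagonist activity at Endothelin-1 receptor (Rattus norvegicus); on this read-out lower numbers stand for stronger inhibition and higher numbers for weaker inhibition:
- compound 1, `Cc1noc(NS(=O)(=O)c2ccc(NCc3ccccc3)cc2)c1C`: 9800 nM
- compound 2, `Cc1noc(NS(=O)(=O)c2cccc([N+](=O)[O-])c2)c1C`: 7800 nM
- compound 3, `CN(C)c1cccc2c(S(=O)(=O)Nc3onc4c3CCCC4)cccc12`: 153000 nM

Compound 1 holds the second highest of these three numbers. Its nearest neighbour is compound 2, whose number sits within the scatter of it, so the two cannot be told apart. The furthest is compound 3, whose number lies well beyond the scatter above compound 1.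

Compound 4, `Cc1noc(NS(=O)(=O)c2ccc(F)cc2)c1C`, differs from compound 1 by fluoro in place of benzylamino on an aromatic carbon. Within the data shown here, no measured pair shows what such a swap does. Without that guide, the step from compound 1 to compound 4 is expected to be small, likely within the scatter, if anything toward a slightly higher number: a 1.5-fold higher number from compound 1 to compound 4 (0.18 log units; within the scatter). Compound 4 is therefore estimated at 15000 nM, with a range from 4000 nM to 55000 nM.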

Compound 4, half-maximal inhibitory concentration: 1000 nM
Beside the measured number, compound 4's estimate is 15-fold (1.18 log units) above it, outside the stated range (below it).
By their numbers in this assay, from the lowest: compound 4; then compounds 2 and 1 (each within the scatter of the next); then compound 3.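

In this assay fluoro in place of benzylamino on the aromatic carbon gives a 9.8-fold lower number from compound 1 to compound 4 (0.99 log units; beyond the scatter). This position therefore does not need the benzylamino group, with its extra aromatic ring and hydrogen-bond donor, for inhibition: a single fluorine atom does better here. Nothing measured here explains why this swap has such an effect.

Among these compounds, with only this one pair, it remains open whether the gain comes from adding fluoro or from losing benzylamino. A plain hydrogen, a chloro group or a methoxy group at this place would help separate the two.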